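A few compounds are considered here, and "the series" means these few. Any claim that something is new, unique, unknown or untested is made for them only; others in the source may bear on it.

Measured so far in an assay on isolated protein for inhibition of serine/threonine-protein kinase TNNI3K (Homo sapiens); a higher number here means a weaker inhibitor, a lower number a stronger inhibitor:
compound 1, `O=C(Nc1ccc(Oc2ccncn2)cc1)Nc1cccc(C(F)(F)F)c1` — 160 nM
compound 2, `O=C(Nc1ccc(Oc2cc(O)ncn2)cc1)Nc1cccc(C(F)(F)F)c1` — 3200 nM
compound 3, `COc1cc(Oc2ccc(NC(=O)Nc3cccc(C(F)(F)F)c3)cc2)ncn1` — 4000 nM

Compound 3 stands at the highest number of the three; the nearer neighbour is within the scatter (a 1.3-fold higher number from compound 2 to compound 3 (0.10 log units; within the scatter)), the farther one well beyond it (a 25-fold higher number from compound 1 to compound 3 (1.40 log units; beyond the scatter)).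

Next is compound 4, `CCCNc1cc(Oc2ccc(NC(=O)Nc3cccc(C(F)(F)F)c3)cc2)ncn1`, which differs from compound 3 in one place: propylamino in place of methoxy on an aromatic carbon.

Bearing on this step are the two substitutions made at the same place of the shared core, a 20-fold higher number from compound 1 to compound 2 (1.30 log units; beyond the scatter) and a 25-fold higher number from compound 1 to compound 3 (1.40 log units; beyond the scatter), both large, and the comparison between the two substituted compounds, a 1.3-fold higher number from compound 2 to compound 3 (0.10 log units; within the scatter), which is within the scatter. Among the measured compounds shown here, no measured compound carries a propylamino group at this place, so the direction for this group is not anchored. Since hydroxy and methoxy land at much the same number, the step expected for compound 4 is one within the scatter, a 1.3-fold lower number from compound 3 to compound 4 (0.12 log units; within the scatter), with a wide range around it. Compound 4 is estimated at 3000 nM, between 700 nM and 13000 nM.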

Compound 4, half-maximal inhibitory concentration: 32 nM
Estimate against measurement, compound 4: 94-fold (1.97 log units) above; the measured number lies below the stated range.
By their numbers in this assay, from the lowest: compound 4; then compound 1; then compounds 2 and 3 (each within the scatter of the next).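

In this assay, substitution at this position of the shared core does not always weaken binding: propylamino gives a 5.0-fold lower number from compound 1 to compound 4 (0.70 log units; beyond the scatter), whereas hydroxy and methoxy both moved the number the other way. The size of the split between these groups is seen in a 130-fold lower number from compound 3 to compound 4 (2.10 log units; beyond the scatter) and a 100-fold lower number from compound 2 to compound 4 (2.00 log units; beyond the scatter), so the closeness of the hydroxy and methoxy compounds said nothing about a substituent attached through nitrogen. No measured data bearing on the reason for this reversal are available.

The compounds shown do not separate the contribution of the attaching nitrogen from that of the propyl chain, a question that a methylamino or propoxy group at this place would address. As far as these compounds go, how a longer chain or a cyclic amine such as morpholine would behave here also remains open.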